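The compounds below may be only part of what the source reports. "The series", "measured", "known", "first", "only" and "open" are said of these compounds alone.

Working notes on the series. Three chalcone-type compounds sharing one core have been measured in a functional assay on B16-F10 cells (Mus musculus) for antiproliferative activity, read by MTT assay, with a stated time of 48 h; on this read-out lower numbers stand for stronger inhibition and higher numbers for weaker inhibition. Compound 1 `CCOc1ccc(C(=O)/C=C/c2c(/C=C/c3ccc(OC)cc3)cc(OC)cc2OC)cc1` gives 6.4 ug/mL. Compound 2 `COc1ccc(/C=C/c2cc(OC)cc(OC)c2/C=C/C(=O)c2ccc(Cl)c(Cl)c2)cc1` gives 7.5 ug/mL. Compound 3 `COc1ccc(/C=C/c2cc(OC)cc(OC)c2/C=C/C(=O)c2cccc(OC)c2)cc1` gives 4.3 ug/mL, the lowest of the three numbers, yet its separations from the others are small: a 1.5-fold lower number from compound 1 to compound 3 (0.17 log units; within the scatter) and a 1.7-fold lower number from compound 2 to compound 3 (0.24 log units; within the scatter), both inside the usual scatter, so no order among the three can be claimed. Going by the values given here, the only variation so far is the aryl group on the carbonyl carbon, and every step there has been flat: a 1.2-fold higher number from compound 1 to compound 2 (0.07 log units; within the scatter) as well.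

Compound 4 `CCN(CC)c1ccc(C(=O)/C=C/c2c(/C=C/c3ccc(OC)cc3)cc(OC)cc2OC)cc1` is not yet measured. It differs from compound 3 as follows: 4-(diethylamino)phenyl in place of 3-methoxyphenyl on a carbonyl carbon. This again changes only the aryl group on the carbonyl carbon, the very place where compounds 1, 2 and 3 differ. All three measured steps at that place were within scatter, so a step of the same kind is expected for compound 4: the expectation is a 1.1-fold higher number from compound 3 to compound 4 (0.05 log units; within the scatter), no change beyond scatter. Compound 4 is therefore estimated at 4.8 ug/mL, with a likely range of 2.4 ug/mL to 9.6 ug/mL.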

Compound 4, half-maximal inhibitory concentration: 8.1 ug/mL
Estimate against measurement, compound 4: 1.7-fold (0.23 log units) below; low and high end bracket the measured number.
By their numbers in this assay, from the lowest: compounds 3, 1, 2 and 4 (each within the scatter of the next).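

In this assay, going by these compounds alone, the aryl group on the carbonyl carbon now also takes a nitrogen-bearing substituent, and 4-(diethylamino)phenyl in place of 3-methoxyphenyl gives a 1.9-fold higher number from compound 3 to compound 4 (0.28 log units; within the scatter), the largest step seen at this place so far but still not one that can be read as a real difference. The same group in place of 3,4-dichlorophenyl gives a 1.1-fold higher number from compound 2 to compound 4 (0.03 log units; within the scatter), and the narrowest change in the series, diethylamino in place of ethoxy on an aromatic carbon, gives a 1.3-fold higher number from compound 1 to compound 4 (0.10 log units; within the scatter), so the flat picture at this place now spans ethoxy, methoxy, dichloro and diethylamino substitution on the aryl group. Nothing available bears on why these numbers stay so close.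

From the compounds shown here alone, whether any group at this place can produce a step beyond the scatter stays open, for instance a carboxylic acid or a primary amine on the aryl group. The compounds shown also vary nothing else, so they leave open how the number responds to changes elsewhere on the shared core, such as replacing its methoxy groups with hydroxy groups or longer alkoxy chains.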